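Replacing phenyl on the shared core: working notes

The source may report more compounds than this note shows. Statements on the series, on what has been measured and on what is new or still open speak of the compounds shown alone.

Measured in a functional assay on CAPAN-1 cells (Homo sapiens) for antiproliferative activity, with a stated time of 72 h; a higher number here means a weaker inhibitor, a lower number a stronger inhibitor:
- compound 1 `Nc1ncnn2c([C@@H]3O[C@H](CO)[C@@H](O)[C@H]3O)cc(-c3ccccc3)c12`: 65200 nM
- compound 2 `Nc1ncnn2c([C@@H]3O[C@H](CO)[C@@H](O)[C@H]3O)cc(-c3ccc(F)cc3F)c12`: 50900 nM
- compound 3 `Nc1ncnn2c([C@@H]3O[C@H](CO)[C@@H](O)[C@H]3O)cc(-c3ccoc3)c12`: 900 nM

Compound 1 lies at the high end of this short series, level with its nearest neighbour: a 1.3-fold lower number from compound 1 to compound 2 (0.11 log units; within the scatter). The next change gives compound 4 `Nc1ncnn2c([C@@H]3O[C@H](CO)[C@@H](O)[C@H]3O)cc(/C=C/c3ccccc3)c12`: 2-phenylethenyl in place of phenyl on an aromatic carbon. The measured step that keeps a six-membered aromatic ring of carbon only stayed small, as shown above. The steps to the furan-3-yl group were large, a 72-fold lower number from compound 1 to compound 3 (1.86 log units; beyond the scatter) and a 57-fold lower number from compound 2 to compound 3 (1.75 log units; beyond the scatter), but that group has no such ring, so they bear less here. In this assay, a slight move to a lower number is expected, probably not beyond the scatter. The expected step is a 1.6-fold lower number from compound 1 to compound 4 (0.21 log units; within the scatter). The estimated value for compound 4 is 40000 nM, with an expected range of 8000 nM to 100000 nM.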

Compound 4, half-maximal inhibitory concentration: 2600 nM
The estimate for compound 4 lay 15-fold (1.19 log units) above the measured number; measured number below the stated range.
By their numbers in this assay, from the lowest: compound 3; then compound 4; then compounds 2 and 1 (each within the scatter of the next).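

At this aromatic carbon, a six-membered aromatic ring of carbon only can give a low number in this assay when carried as 2-phenylethenyl, with a 25-fold lower number from compound 1 to compound 4 (1.40 log units; beyond the scatter) and a 20-fold lower number from compound 2 to compound 4 (1.29 log units; beyond the scatter). A large drop is therefore no longer confined to furan-3-yl, although a 2.9-fold higher number from compound 3 to compound 4 (0.46 log units; beyond the scatter) keeps that group at the lower number. Nothing available accounts for these steps.

The compounds shown leave open whether the double bond or the longer reach of the group goes with the lower number. A 2-phenylethyl group would separate the two.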